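Aryl swap on the sulfonamide: compound 2 to compound 4

The source may hold more compounds than are shown below. What is called first, only, known or untested is meant among the compounds shown, and "the series" means these compounds.

Measured in a functional assay on cells (leukaemia cell line, Homo sapiens) for inhibition, read by sulforhodamine B assay, with a stated time of 48 h; on this read-out higher numbers stand for lower toxicity in this test and lower numbers for higher toxicity in this test:
- compound 1 `O=S(=O)(Nc1cccc(Cl)c1)c1ccc(-c2cnc(C3CC3)o2)cc1`: > 100000 nM
- compound 2 `Cc1cc(NS(=O)(=O)c2ccc(-c3cnc(C4CC4)o3)cc2)ccc1Cl`: > 100000 nM
- compound 3 `Cc1ccc(NS(=O)(=O)c2ccc(-c3cnc(C4CC4)o3)cc2)cc1C`: > 100000 nM

Compound 2 reads > 100000 nM, which is a limit and not a number. It has company there, with the limit of > 100000 nM in this assay, at which 3 of the 3 values shown sit.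

Compound 4 `O=S(=O)(Nc1cc(F)cc(F)c1)c1ccc(-c2cnc(C3CC3)o2)cc1` keeps the shared core and differs only on a sulfonamide nitrogen, where 3,5-difluorophenyl takes the place of 4-chloro-3-methylphenyl: 3,5-difluorophenyl in place of 4-chloro-3-methylphenyl on a sulfonamide nitrogen. Going by the values given here, no measured compound carries the entering group.

Among the compounds with values here, three measured steps bear on this change: a step that the two limits leave unreadable from compound 1 to compound 2, a step that the two limits leave unreadable from compound 1 to compound 3 and a step that the two limits leave unreadable from compound 2 to compound 3. Within the data shown here, the first two change the group on the same nitrogen, and the third changes a single group on that ring. None of the three has a readable size, so they set no size for the new step and give it no direction.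

All three aryl groups tried so far end at the limit, so the working expectation is that compound 4 joins them, with no step beyond the usual scatter in this assay. The expected move is a number no higher from compound 2 to compound 4 (the limit leaves the size open).

The estimate for compound 4 is 100000 nM, with an expected range from 40000 nM to 200000 nM.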

Compound 4, concentration lethal to 50% of the cells: > 100000 nM
Compound 4 was reported as a limit; the forecaster's own chance of this, stated with the estimate: 85%; the middle value lies on the limit itself.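

In this assay compound 4 gives > 100000 nM, which is a limit and not a number. No step among compound 1, compound 2, compound 3 and compound 4 can be read, and the position of all four is shared: the limit of > 100000 nM in this assay, at which 4 of the 4 values shown sit.

The compounds shown leave open whether any aryl group on the sulfonamide nitrogen gives a measurable value in this assay.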